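A few compounds are considered here, and "the series" means these few. Any claim that something is new, unique, unknown or untested is made for them only; others in the source may bear on it.

Series notes. Compound 1 `COc1ccc(CC2CCCCN2C(=O)n2ncc(C(O)(c3ccc(F)cc3)c3ccc(F)cc3)n2)cc1`, compound 2 `O=C(N1C[C@@H](O)C=C[C@@H]1Cc1ccccc1)n1ncc(C(O)(c2ccc(F)cc2)c2ccc(F)cc2)n1` and compound 3 `COC(c1ccc(F)cc1)(c1ccc(F)cc1)c1cnn(C(=O)N2CCCCC2Cc2ccccc2)n1` share the same core and have all been run in an assay on HEK-293T cells for inhibition of diacylglycerol lipase-alpha (Homo sapiens), read by colorimetric assay; on this read-out higher numbers stand for weaker inhibition and lower numbers for stronger inhibition. Compound 1 gives 5.01 nM in this assay, compound 2 gives 20 nM and compound 3 gives 12.6 nM. Among these three numbers compound 3 stands second highest: its nearest neighbour is compound 2, whose number lies within the scatter of it, while compound 1 is furthest off, with a lower number beyond the scatter.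

Compound 4 `O=C(N1CCCCC1Cc1ccccc1)n1ncc(C(O)(c2ccc(F)cc2)c2ccc(F)cc2)n1` has not yet been measured. It is reached from compound 3 by hydrogen in place of methyl on an oxygen on a saturated carbon. For the measured compounds named here, no pair of measured compounds isolates this change; compound 1 and compound 2 both carry the hydroxy form, but each differs from compound 3 elsewhere as well, so their values only show that hydroxy-bearing members of this set fall on both sides of compound 3.

Because in this assay compound 1 gives 5.01 nM and is the nearest hydroxy-bearing neighbour of compound 3, the expected step from compound 3 to compound 4 is a 1.8-fold lower number from compound 3 to compound 4 (0.26 log units; within the scatter), a modest move toward a lower number that may not clear the scatter. Compound 4 is accordingly estimated at 7 nM in this assay, with a range from 2.5 nM to 20 nM.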

Compound 4, half-maximal inhibitory concentration: 1 nM
Compound 4: the middle estimate sits 7.0-fold (0.85 log units) above what was measured, and the stated range ends above it.
By their numbers in this assay, from the lowest: compound 4; then compound 1; then compounds 3 and 2 (each within the scatter of the next).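

With the other parts of the molecule held constant in this assay, the methoxy to hydroxy change on the saturated carbon gives a large gain in inhibition (a 13-fold lower number from compound 3 to compound 4 (1.10 log units; beyond the scatter)), so this position responds strongly to what sits on the oxygen, which compound 1 and compound 2 could not show since each differs from compound 3 elsewhere as well. A second single-place comparison shows that the methoxy group on an aromatic carbon of compound 1 is not needed for strong inhibition in this set: hydrogen in its place gives a modest but real move to a lower number (a 5.0-fold lower number from compound 1 to compound 4 (0.70 log units; beyond the scatter)). The data shown offer no measurement that would explain either step.

From the compounds shown here alone, whether the direction seen on the oxygen extends to a longer chain such as ethyl, or to an amine or a fluorine atom in place of the hydroxy, remains open. Also open, going by these compounds, is whether groups other than methoxy on that aromatic carbon, such as chlorine or a carboxylic acid, would keep or lose the low number of compound 4.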